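The source may report more compounds than this note shows. Statements on the series, on what has been measured and on what is new or still open speak of the compounds shown alone.

Going by the values given here, in a functional assay on DU-145 cells (Homo sapiens) for inhibition, read by trypan blue exclusion, with a stated time of 96 h (on this read-out higher numbers stand for weaker inhibition of growth and lower numbers for stronger inhibition of growth), compound 2 `O=C(/C(=C\c1c(O)cc(O)cc1O)SCc1ccc(Cl)c(Cl)c1)c1ccc(Cl)cc1` gives 25000 nM as the higher of the two numbers so far, and compound 1 `COc1ccccc1/C=C(/SCc1ccc(Cl)c(Cl)c1)C(=O)c1ccc(Cl)cc1` gives 10000 nM as the lower. The change to compound 3 `COc1ccc(OC)c(/C=C(/SCc2ccc(Cl)c(Cl)c2)C(=O)c2ccc(Cl)cc2)c1` is 2,5-dimethoxyphenyl in place of 2,4,6-trihydroxyphenyl on a double-bonded chain carbon bound to a double-bonded chain carbon with 2,5-dimethoxyphenyl replacing 2,4,6-trihydroxyphenyl. Among the compounds with values here, the one measured step that bears on this is a 2.5-fold higher number from compound 1 to compound 2 (0.40 log units; beyond the scatter) and it brought in that same 2,4,6-trihydroxyphenyl with a modest rise in the number. Removing the group might roughly reverse that rise. In this assay a modest fall of similar size is therefore expected, a 2.8-fold lower number from compound 2 to compound 3 (0.44 log units; beyond the scatter). Compound 3 is estimated at 9000 nM with a range from 3000 nM to 25000 nM.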

Compound 3, concentration for 50% growth inhibition: 10000 nM
Beside the measured number, compound 3's estimate is 1.1-fold (0.05 log units) below it; the measured number falls inside the stated range.
By their numbers in this assay, from the lowest: compounds 1 and 3 (each within the scatter of the next); then compound 2.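

Replacing 2,4,6-trihydroxyphenyl with 2,5-dimethoxyphenyl on a double-bonded chain carbon bound to a double-bonded chain carbon gives a modest fall in this assay (a 2.5-fold lower number from compound 2 to compound 3 (0.40 log units; beyond the scatter)). Adding methoxy in place of hydrogen on an aromatic carbon shows no change at the digits printed from compound 1 to compound 3 (within the scatter), so this added group makes no measurable difference here. Nothing available explains either result.

The step from compound 2 to compound 3 swaps the whole substituted ring, so it cannot separate the effect of removing the hydroxy groups from that of adding methoxy groups. From the compounds shown here alone, how an amine or a carboxylic acid on this ring would read remains open.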